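This account rests on a few compounds, and the source may have more. Where it says the series, first, only, none or still open, it means among the compounds named here.

Measured so far in an assay for inhibition of Fatty-acid amide hydrolase 1 (Rattus norvegicus), using a Dixon plot; on this read-out higher numbers stand for weaker inhibition and lower numbers for stronger inhibition:
Compound 1 `O=C(CCCCCCc1ccccc1)c1ncc(-c2ccc(CCl)cn2)o1`; compound 1 gives 22.4 nM.
Compound 2 `CSCc1ccc(-c2cnc(C(=O)CCCCCCc3ccccc3)o2)nc1`; compound 2 gives 11.1 nM.
Compound 3 `O=C(CCCCCCc1ccccc1)c1ncc(CCCCCCl)o1`; compound 3 gives 5.2 nM.

Compound 2 differs from compound 1 by methylsulfanyl in place of chloro on a saturated chain carbon bound to an aromatic carbon. This change made a 2.0-fold lower number from compound 1 to compound 2 (0.30 log units; within the scatter). The core of compound 3 differs from that of compound 1 by a group of 6 heavy atoms (5 carbon, 1 chlorine; no ring) in place of a group of 8 heavy atoms (6 carbon, 1 nitrogen, 1 chlorine; one six-membered aromatic ring with 1 hetero atom), on an aromatic carbon, a change that made a 4.3-fold lower number from compound 1 to compound 3 (0.63 log units; beyond the scatter). Compound 2 against compound 3 shows a 2.1-fold lower number from compound 2 to compound 3 (0.33 log units; beyond the scatter). Compound 3 stands at the lowest number of the three, with both its steps beyond the scatter.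

Compound 4 `CSCCCCCc1cnc(C(=O)CCCCCCc2ccccc2)o1` has not yet been measured in this assay. It differs from compound 3 by methylsulfanyl in place of chloro on a saturated chain carbon, five bonds along the chain from an aromatic carbon. The place is not the same as in the first pair: there the saturated chain carbon is bound to an aromatic carbon, here it lies five bonds along the chain from an aromatic carbon, so this is the same kind of change, not the same change. For compound 4 a step of about a 1.5-fold lower number from compound 3 to compound 4 (0.17 log units; within the scatter) is expected, because a 2.0-fold lower number from compound 1 to compound 2 (0.30 log units; within the scatter) is the only shown case of this kind of change and it stayed within the scatter. Compound 4 is therefore estimated at 3.5 nM, expected between 1.4 nM and 9 nM.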

Compound 4, inhibition constant: 8.1 nM
Estimate against measurement, compound 4: 2.3-fold (0.36 log units) below, within the range that was stated.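

Carrying chloro to methylsulfanyl from one core to another in this assay does not give a fixed step: the same change on two cores in this assay, a 2.0-fold lower number (0.30 log units; within the scatter) from compound 1 to compound 2 and a 1.6-fold higher number (0.19 log units; within the scatter) from compound 3 to compound 4, 3.1-fold (0.50 log units) apart, beyond the scatter of two such steps.

Each step alone stays within the scatter, so neither shows an effect of the change by itself, and the chain carbon carrying the group is not the same in the two pairs, which leaves the gap unassigned between core and place. The comparisons with the ring-bearing compounds read differently, with a 1.4-fold lower number from compound 2 to compound 4 (0.14 log units; within the scatter) when methylsulfanyl stands in both compounds, and a 2.8-fold lower number from compound 1 to compound 4 (0.44 log units; beyond the scatter) when the chloro compound is the starting point, while the step on the chain core itself is a 1.6-fold higher number from compound 3 to compound 4 (0.19 log units; within the scatter) and these steps give no ranking of chloro against methylsulfanyl.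

Still open, going by these compounds, is whether a third core would give a step closer to one pair or the other. Also open, on these data alone, is how an amine or a carboxylic acid would read in place of chloro on that saturated chain carbon, five bonds along the chain from an aromatic carbon.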